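Replacing the amine nitrogen substituent of compound 1

The source may hold more compounds than are shown below. What is called first, only, known or untested is meant among the compounds shown, and "the series" means these compounds.

In a functional assay on HepG2 cells (Homo sapiens) for cytotoxicity, read by MTT assay, with a stated time of 24 h (a higher number here means a weaker inhibitor, a lower number a stronger inhibitor), compound 1 `CN1C/C(=C\c2cccnc2)C(=O)/C(=C/c2ccccc2F)C1` gives 4810 nM and compound 2 `CN1C/C(=C\c2cccnc2)C(=O)/C(=C/c2cc([N+](=O)[O-])ccc2F)C1` gives 6630 nM. Going by the values given here, these are the only two numbers so far and they lie within the scatter of each other, so compound 1 has no clear rank. Compound 3 `Cc1ccc(S(=O)(=O)N2C/C(=C\c3cccnc3)C(=O)/C(=C/c3ccccc3F)C2)cc1` keeps the core of compound 1 but carries (4-methylphenyl)sulfonyl in place of methyl on an amine nitrogen in a ring. Among the compounds with values here, the only measured step, a 1.4-fold higher number from compound 1 to compound 2 (0.14 log units; within the scatter), puts nitro in place of hydrogen on an aromatic carbon and stays within the scatter. Within the data shown here, no measured compound varies the amine nitrogen, so that step offers only weak guidance. No shift beyond the scatter is firmly expected in this assay, but the range is kept wide. The estimated step is a 1.2-fold lower number from compound 1 to compound 3 (0.08 log units; within the scatter), with no firm direction. For compound 3 the expected value is 4000 nM, with an estimated range of 1200 nM to 13000 nM.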

Compound 3, half-maximal inhibitory concentration: 4200 nM
For compound 3 the middle estimate is 1.1-fold (0.02 log units) below the measured one, within the range that was stated.
By their numbers in this assay, from the lowest: compounds 3, 1 and 2 (each within the scatter of the next).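

In this assay the amine nitrogen in the ring now has a measured change: (4-methylphenyl)sulfonyl in place of methyl (a 1.1-fold lower number from compound 1 to compound 3 (0.06 log units; within the scatter)). The earlier step concerned only an aromatic carbon, whereas this one shows that the nitrogen can carry a group with a six-membered aromatic ring and a sulfonyl unit with no shift beyond the scatter. No measured evidence accounts for the size of this step.

On these data alone, how a longer alkyl chain, a carboxylic acid or an amine on this nitrogen would read remains open. Also open, as far as these compounds go, is whether (4-methylphenyl)sulfonyl would give a similarly small step on the nitro-bearing compound 2.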